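Oxadiazole substituent changes and human liver microsomal half-life

The compounds below may be only part of what the source reports. "The series", "measured", "known", "first", "only" and "open" are said of these compounds alone.

Compound 1 `CN1CCN(Cc2nnc(-c3cc(S(N)(=O)=O)c(SCc4ccccc4)cc3Cl)o2)CC1`: 0.308 h
Compound 2 `CCOC(=O)c1cn(Cc2nnc(-c3cc(S(N)(=O)=O)c(SCc4ccccc4)cc3Cl)o2)nn1`: 0.085 h
Compound 3 `NS(=O)(=O)c1cc(-c2nnc(CNC(=O)c3ccccc3)o2)c(Cl)cc1SCc1ccccc1`: 0.187 h

Three compounds sharing one core were measured in an ADME assay on microsomes from liver (Homo sapiens) for metabolic stability, read by LC-MS, using NADPH, tested at 5 uM; a lower number here means that the compound disappears faster, a higher number that the compound lasts longer. Compound 3 has the second highest number of the three: its nearest neighbour is compound 1, with a step of a 1.6-fold lower number from compound 1 to compound 3 (0.22 log units; within the scatter), and the furthest is compound 2, with a 2.2-fold higher number from compound 2 to compound 3 (0.34 log units; beyond the scatter).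

Compound 4 `NS(=O)(=O)c1cc(-c2nnc(/C=C/c3c(Cl)cccc3Cl)o2)c(Cl)cc1SCc1ccccc1` carries 2-(2,6-dichlorophenyl)ethenyl in place of benzamidomethyl on an aromatic carbon. Every measured step concerned the group on the same side of the shared core: a 3.6-fold lower number from compound 1 to compound 2 (0.56 log units; beyond the scatter), a 1.6-fold lower number from compound 1 to compound 3 (0.22 log units; within the scatter) and a 2.2-fold higher number from compound 2 to compound 3 (0.34 log units; beyond the scatter), all modest or within the scatter. Within the data shown here, no measured compound lacks both the hydrogen-bond donor and the acceptor of that group, so the present change is not closely covered. Compound 4 is therefore expected to show a step of about a 1.1-fold higher number from compound 3 to compound 4 (0.03 log units; within the scatter) in this assay, with a half-life estimated at 0.2 h, between 0.08 h and 0.5 h.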

Compound 4, half-life: 0.468 h
For compound 4 the middle estimate is 2.3-fold (0.37 log units) below the measured one; low and high end bracket the measured number.
By their numbers in this assay, from the lowest: compound 2; then compounds 3, 1 and 4 (each within the scatter of the next, the first and the last beyond it).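

In this assay, a group at this position needs neither a hydrogen-bond donor nor an acceptor to last as long as the others: 2-(2,6-dichlorophenyl)ethenyl, which has neither, gives a 2.5-fold higher number from compound 3 to compound 4 (0.40 log units; beyond the scatter) and a 5.5-fold higher number from compound 2 to compound 4 (0.74 log units; beyond the scatter). Against the (4-methylpiperazin-1-yl)methyl group, it gives a 1.5-fold higher number from compound 1 to compound 4 (0.18 log units; within the scatter), so the amine offers no clear advantage over it. Nothing available explains these steps. The compounds shown leave open whether the two chlorine atoms, the ethenyl link or the loss of the amide carries the step. An unsubstituted 2-phenylethenyl group or a saturated 2-(2,6-dichlorophenyl)ethyl chain would separate these.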